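The source may hold more compounds than are shown below. What is called first, only, known or untested is meant among the compounds shown, and "the series" means these compounds.

Measured so far:
Compound 1 `CCc1ccc(-c2nn3cc(-c4cccc(N)c4)nc3s2)cc1` gives 22000 nM in a functional assay on CCRF-CEM cells (Homo sapiens) for inhibition, read by cell counting, with a stated time of 3 days; a higher number here means a weaker inhibitor, a lower number a stronger inhibitor.
Compound 2 `C=C(Br)C(=O)Nc1cccc(-c2cn3nc(-c4ccc(CC)cc4)sc3n2)c1` gives 3400 nM in this assay.

Among these two, compound 1 has the higher number, and the only step, a 6.5-fold lower number from compound 1 to compound 2 (0.81 log units; beyond the scatter), changes a different part of the molecule. Compound 3 `CCOc1ccc(-c2nn3cc(-c4cccc(N)c4)nc3s2)cc1` differs from compound 1 by ethoxy in place of ethyl on an aromatic carbon. Among the measured compounds shown here, no measured step touches this position, so there is no direct guide, and the change is small; the step of no change at the digits printed from compound 1 to compound 3 (within the scatter) is expected to stay within the scatter. Compound 3 is therefore estimated at 22000 nM in this assay, with a likely range from 7000 nM to 70000 nM.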

Compound 3, half-maximal inhibitory concentration: > 250000 nM
Compound 3 gave a limit, no number; the forecaster's own chance of this, stated with the estimate: 5%; middle value at least 11-fold (1.05 log units) from the limit.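

Ethoxy in place of ethyl on this aromatic carbon brings an at least 11-fold higher number from compound 1 to compound 3 (1.05 log units; beyond the scatter), so this position is far from indifferent, and even a small change here can matter greatly. The reading for compound 3 is a limit of the assay, not a number: the limit of > 250000 nM in this assay, at which 1 of the 3 values shown sits.

The compounds shown leave open whether the oxygen itself or simply the larger group drives this loss. On these data alone, how a methoxy or a propyl group would behave at this position also remains open, and either could help separate those two possibilities.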